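A few compounds are considered here, and "the series" means these few. Any claim that something is new, unique, unknown or untested is made for them only; others in the source may bear on it.

Measured compounds:
Compound 1, `O=C(CCCCCc1ccccc1)c1nc2ccccc2s1`. In an assay on HEK-293T cells for inhibition of diacylglycerol lipase-alpha (Homo sapiens), read by colorimetric assay (on this read-out lower numbers stand for stronger inhibition and higher numbers for weaker inhibition), compound 1 gives > 10000 nM, which is a limit of the assay and not a number.
Compound 2, `CC(=O)c1cnc(C(=O)CCCCCCc2ccccc2)o1`. In this assay compound 2 gives > 10000 nM, again a limit of the assay rather than a number.

Compound 2 therefore stands at the limit of > 10000 nM in this assay, at which 2 of the 2 values shown sit, with no numerical potency in this assay to set it apart from compound 1. The step under consideration alters the substituent on the oxazole: methylamino in place of methyl on a carbonyl carbon, giving compound 3, `CNC(=O)c1cnc(C(=O)CCCCCCc2ccccc2)o1`. Among the compounds with values here, no step between two measured compounds is available to guide the size of this change. As compound 2 sits at the assay limit, the step from compound 2 to compound 3 is expected to be a step that the limit leaves unreadable from compound 2 to compound 3, most likely no movement beyond the scatter into measurable potency. Compound 3 is accordingly estimated at 20000 nM, within a range from 5000 nM to 100000 nM.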

Compound 3, half-maximal inhibitory concentration: > 10000 nM
Compound 3 ended at the assay's limit (the forecaster's own chance of this, stated with the estimate: 75%); the middle value does not contradict the limit.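

In this assay compound 3 gives > 10000 nM, which is a limit of the assay and not a number. The change from compound 2 to compound 3 cannot be read as a step. The compounds shown leave open what numerical potency, if any, each of them has.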